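The source may report more compounds than this note shows. Statements on the series, on what has been measured and on what is new or still open speak of the compounds shown alone.

Measured compounds:
Compound 1 `O=c1cc(CNCc2cccc(F)c2)oc2ccc(O)c(O)c12`: in an ADME assay on Huh-7 cells (Homo sapiens) for cytotoxicity (on this read-out lower numbers stand for higher toxicity in this test and higher numbers for lower toxicity in this test), compound 1 gives > 100000 nM, which is a limit of the assay.
Compound 2 `O=c1cc(CNCc2cccc(Br)c2)oc2ccc(O)c(O)c12`: in this assay compound 2 gives > 100000 nM, again only a limit.
Compound 3 `O=c1cc(CNCc2ccc(Cl)cc2)oc2ccc(O)c(O)c12`: in this assay compound 3 gives > 100000 nM, also a limit.

Compound 3 therefore stands at the limit of > 100000 nM in this assay, at which 3 of the 3 values shown sit, with no number of its own. The measured steps a step that the two limits leave unreadable from compound 1 to compound 2, a step that the two limits leave unreadable from compound 1 to compound 3 and a step that the two limits leave unreadable from compound 2 to compound 3 run between limits and their sizes cannot be read; the first of them is the nearest kind of change, a heavier halogen on an aromatic carbon. Compound 4 `O=c1cc(CNCc2ccc(Br)cc2)oc2ccc(O)c(O)c12` differs from compound 3 by bromo in place of chloro on an aromatic carbon. On these values no step beyond the scatter is expected in this assay, and compound 4 is expected to sit at the same limit. Compound 4 is estimated at 150000 nM, within 80000 nM to 300000 nM. The expected step is a step that the limit leaves unreadable from compound 3 to compound 4.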

Compound 4, half-maximal cytotoxic concentration: > 100000 nM
Compound 4 ended at the assay's limit (the forecaster's own chance of this, stated with the estimate: 90%); the middle value lies beyond the limit too.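

No step among compound 1, compound 2, compound 3 and compound 4 can be read, because all four values are limits: the limit of > 100000 nM in this assay, at which 4 of the 4 values shown sit.

The compounds shown leave open whether halogen identity or position changes the half-maximal cytotoxic concentration at all.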